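This account rests on a few compounds, and the source may have more. Where it says the series, first, only, none or still open, it means among the compounds named here.

In an assay on isolated protein for inhibition of Dihydrofolate reductase (Mus musculus) (on this read-out lower numbers stand for lower potency and higher numbers for higher potency (the scale is a negative logarithm)), compound 1 `CC1(C)N=C(N)N=C(N)N1c1ccc(OCCCNC(=O)c2ccc(S(=O)(=O)F)cc2)c(Cl)c1` gives 7.34, the lowest of the three numbers recorded for this set of compounds sharing the same core. Compound 3 `CC1(C)N=C(N)N=C(N)N1c1ccc(OCc2ccc(S(=O)(=O)F)cc2Cl)c(Cl)c1` gives 7.44, a value that sits within the usual scatter of compound 1, so the two cannot be told apart. Compound 2 `CC1(C)N=C(N)N=C(N)N1c1cccc(CNC(=O)Nc2cccc(Cl)c2)c1` gives 8.05, which lies beyond the scatter above compound 1 and is the highest of the three values.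

Compound 4 `CC1(C)N=C(N)N=C(N)N1c1ccc(OCCCNC(=O)Nc2cccc(S(=O)(=O)F)c2)c(Cl)c1` has not yet been measured. It differs from compound 1 in one place, ((3-(fluorosulfonyl)phenyl)amino in place of 4-(fluorosulfonyl)phenyl on a carbonyl carbon), so the group bound to the carbonyl carbon gains a hydrogen-bond donor while the 3-(fluorosulfonyl)phenyl ring remains attached through a nitrogen. For the measured compounds named here, no step between measured compounds that isolates this kind of change is available, so the direction has to be judged from the spread of values alone. Given that compound 2 reaches 8.05 while compound 1 sits at 7.34, compound 4 is expected to move by a number 0.26 log units higher from compound 1 to compound 4 (within the scatter), a small step upward, though one that may not clear the scatter. Compound 4 is therefore estimated at 7.6, with a range from 7 to 8.2.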

Compound 4, logarithm of the reciprocal of the active concentration, log(1/C): 7.28
The estimate for compound 4 lay 0.32 log units above the measured number, within the range that was stated.
By their numbers in this assay, from the lowest: compounds 4, 1 and 3 (each within the scatter of the next); then compound 2.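

In this assay, putting (3-(fluorosulfonyl)phenyl)amino in place of 4-(fluorosulfonyl)phenyl on a carbonyl carbon gives a number 0.06 log units lower from compound 1 to compound 4 (within the scatter) and so leaves the two compounds indistinguishable. For the compounds shown here, this is the first step in the set that reads this position directly, and it shows that this exchange, which brings in a nitrogen and a hydrogen-bond donor while keeping the fluorosulfonyl-bearing ring, produces no difference that can be resolved on this read-out. Nothing available bears on the reason for this result.

The step carries the entering nitrogen and the change from the 4-(fluorosulfonyl)phenyl to the 3-(fluorosulfonyl)phenyl name together, so what each contributes on its own remains unresolved, and the near-identical numbers could reflect either no contribution from both or two contributions that cancel. Also open, as far as these compounds go, is whether a different group on this carbonyl carbon, such as a plain phenyl, a pyridine or a phenyl ring carrying a carboxylic acid in place of the fluorosulfonyl group, would move the number beyond the scatter.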